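Swapping 2-ethoxyethyl for 4-cyanobenzyl on a shared core

The source may hold more compounds than are shown below. What is called first, only, known or untested is meant among the compounds shown, and "the series" means these compounds.

Compound 3 (`CCOCCOc1ccc(C(O)C2OC(=O)c3c(OC)cc(OC)cc32)cc1`) belongs to a small series built on one shared core. In an ADME assay on RAW264.7 cells (Mus musculus) for cytotoxicity, read by MTT assay, with a stated time of 24 h, in the presence of a further agent that is not named here (on this read-out higher numbers stand for weaker inhibition and lower numbers for stronger inhibition), compound 3 gives > 40000 nM and this is a limit of the assay, not a number. In this assay compound 1 (`CCCCCCOc1ccc(C(O)C2OC(=O)c3c(OC)cc(OC)cc32)cc1`) gives > 40000 nM and this too is only a limit. Compound 2 (`COCCCCOc1ccc(C(O)C2OC(=O)c3c(OC)cc(OC)cc32)cc1`) gives > 40000 nM and this is also a limit. The whole picture so far is therefore the limit of > 40000 nM in this assay, at which 3 of the 3 values shown sit, and no true number is available.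

Compound 4 (`COc1cc(OC)c2c(c1)C(C(O)c1ccc(OCc3ccc(C#N)cc3)cc1)OC2=O`) carries 4-cyanophenyl in place of ethoxymethyl on a saturated chain carbon bound to an oxygen on an aromatic ring. Put another way, 2-ethoxyethyl gives way to 4-cyanobenzyl.

The measured changes on this chain are a step that the two limits leave unreadable from compound 1 to compound 2 and a step that the two limits leave unreadable from compound 1 to compound 3 and a step that the two limits leave unreadable from compound 2 to compound 3 so none of them has a size to carry over. None of them brings in a ring either. Nothing measured points in a direction, and compound 3 stays at > 40000 nM as a limit. The expected change is a number no higher from compound 3 to compound 4 (the limit leaves the size open) and no step beyond the scatter is expected in this assay for now. For compound 4 the estimated value is 40000 nM with 12000 nM to 80000 nM as the expected range.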

Compound 4, half-maximal inhibitory concentration: > 40000 nM
Compound 4: no number, only a limit; the forecaster's own chance of this, stated with the estimate: 70%; the middle value lies on the limit itself.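

In this assay compound 4 gives > 40000 nM, which is a limit and not a number. The steps to compound 4 from compound 1, compound 2 and compound 3 cannot be read. The whole series now rests on one point: the limit of > 40000 nM in this assay, at which 4 of the 4 values shown sit. The compounds shown leave open whether swapping these side chains on the shared core changes cytotoxicity at all.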